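This account rests on a few compounds, and the source may have more. Where it says the series, first, only, none or still open, it means among the compounds named here.

Compounds measured in an assay on isolated protein for inhibition of Gonadotropin-releasing hormone receptor (Homo sapiens); a lower number here means a stronger inhibitor, a higher number a weaker inhibitor:
compound 1 `CCCn1c(SCc2cc([N+](=O)[O-])ccc2OC)nc2cc(NC(=O)NC(C)(C)C)ccc21` — 18 nM
compound 2 `CCCCn1c(SCc2cc([N+](=O)[O-])ccc2OC)nc2cc(NC(=O)NC(C)(C)C)ccc21` — 23 nM
compound 3 `CCCCCn1c(SCc2cc([N+](=O)[O-])ccc2OC)nc2cc(NC(=O)NC(C)(C)C)ccc21` — 210 nM

Compound 1 gives the lowest number of the three in this assay; compound 2 sits within the scatter of it (a 1.3-fold higher number from compound 1 to compound 2 (0.11 log units; within the scatter)), while compound 3 lies beyond it (a 12-fold higher number from compound 1 to compound 3 (1.07 log units; beyond the scatter)). Compound 4 `CCCn1c(SCc2cc([N+](=O)[O-])ccc2OC)nc2cc(NC(=O)NC(C)(C)C)cc(C(=O)NC(C)(C)C)c21` is compound 1 with (tert-butyl)carbamoyl in place of hydrogen on an aromatic carbon. Within the data shown here, all measured steps vary only the chain on the aromatic nitrogen; none touches the fused core, so no measured step bears on this change and the series gives it no precedent. Among the measured compounds shown here, the chain steps show only that this core tolerates some changes and is hurt well beyond the scatter by others. For compound 4 the number is therefore estimated loosely, as 40 nM (range 8 nM to 200 nM), which means an expected step of a 2.2-fold higher number from compound 1 to compound 4 (0.35 log units; beyond the scatter).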

Compound 4, half-maximal inhibitory concentration: 410 nM
Beside the measured number, compound 4's estimate is 10-fold (1.01 log units) below it; measured number outside the range, above it.
By their numbers in this assay, from the lowest: compounds 1 and 2 (each within the scatter of the next); then compounds 3 and 4 (each within the scatter of the next).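

In this assay, placing (tert-butyl)carbamoyl on this aromatic carbon, ortho to a fused ring, gives a large loss (a 23-fold higher number from compound 1 to compound 4 (1.36 log units; beyond the scatter)). Among these compounds, this is the first measured change on the shared core rather than on the chain on the aromatic nitrogen, and it shows that this carbon does not accept this group without cost. Nothing on hand explains the step. Open, from the compounds shown here alone, is whether a methyl, a carboxylic acid or an unsubstituted carboxamide on this carbon would cost as much. Also open, going by these compounds, is whether the tert-butyl or the carbonyl part of the entering group carries the loss.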